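The source may report more compounds than this note shows. Statements on the series, on what has been measured and on what is new or still open speak of the compounds shown alone.

Compound 3, `CC1CCN(C2CCN(S(=O)(=O)c3ccc(F)cc3F)CC2)CC1`, stands only at a limit in an ADME assay on HCT-116 cells (Homo sapiens) for cytotoxicity, read by CellTiter-Glo, with a stated time of 72 h; a lower number here means a stronger inhibitor, a higher number a weaker inhibitor: in this assay compound 3 gives > 5000 nM, which is a limit of the assay and not a number. The two compounds beside it also rest at limits. In this assay compound 1, `CC1CCN(C2CCN(S(=O)(=O)c3cccc(Br)c3)CC2)CC1`, gives > 5000 nM, again a limit. In this assay compound 2, `Cc1noc(C)c1S(=O)(=O)N1CCC(N2CCC(C)CC2)CC1`, gives > 10000 nM, also a limit. The three steps among them, a step that the two limits leave unreadable from compound 1 to compound 2, a step that the two limits leave unreadable from compound 1 to compound 3 and a step that the two limits leave unreadable from compound 2 to compound 3, therefore carry no readable size, because the limit of > 10000 nM in this assay, at which 1 of the 3 values shown sits, and the limit of > 5000 nM in this assay, at which 2 of the 3 values shown sit, are where all three values sit.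

Compound 4, `CC1CCN(C2CCN(S(=O)(=O)c3cnc(Cl)s3)CC2)CC1`, differs from compound 3 by 2-chloro-1,3-thiazol-5-yl in place of 2,4-difluorophenyl on a sulfonyl sulfur. The measured steps that bear on this change are the three just named, each a swap of the group on the sulfonyl sulfur, and each unreadable. Among the measured compounds shown here, no step in this assay shows a change beyond the scatter for any such swap, so no direction can be drawn from them, and the expectation is that compound 4 likewise remains at a limit. The expected step is a step that the limit leaves unreadable from compound 3 to compound 4. The estimate for compound 4 in this assay is 7000 nM, with a range from 3000 nM to 20000 nM.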

Compound 4, half-maximal inhibitory concentration: > 10000 nM
Compound 4: a limit, no number; the forecaster's own chance of this, stated with the estimate: 85%; middle value at least 1.4-fold (0.15 log units) away from the limit.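

In this assay compound 4 gives > 10000 nM, a limit and not a number. Among the compounds shown here, no step from compound 1, compound 2 or compound 3 to compound 4 can be read. The compounds shown leave open whether any group on the sulfonyl sulfur changes the read-out in this assay, and by how much.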